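Phenyl replaced by esters: expectation for compound 4

The compounds below may be only part of what the source reports. "The series", "measured", "known", "first", "only" and "open" are said of these compounds alone.

Measured in a functional assay on B16 cells (Mus musculus) for cytotoxicity, read by MTT assay, with a stated time of 48 h; on this read-out lower numbers stand for stronger inhibition and higher numbers for weaker inhibition:
- compound 1 `O=C(NCc1cn(Cc2ccccc2)nn1)c1cn(Cc2ccccc2)nn1`: 300 nM
- compound 2 `CCOC(=O)Cn1cc(CNC(=O)c2cn(Cc3ccccc3)nn2)nn1`: 35000 nM
- compound 3 `CC(=O)OCCn1cc(CNC(=O)c2cn(Cc3ccccc3)nn2)nn1`: 28000 nM

Compound 1 has the lowest number of the three. Compound 4 `O=C(Cn1cc(C(=O)NCc2cn(Cc3ccccc3)nn2)nn1)OCc1ccccc1`, not yet measured, carries benzyloxycarbonyl in place of phenyl on a saturated chain carbon bound to an aromatic nitrogen. Two measured replacements at that place bear on it, both large: a 120-fold higher number from compound 1 to compound 2 (2.07 log units; beyond the scatter) and a 93-fold higher number from compound 1 to compound 3 (1.97 log units; beyond the scatter). Nothing separates those two replacements: a 1.3-fold lower number from compound 2 to compound 3 (0.10 log units; within the scatter). Among the compounds with values here, the entering group keeps one six-membered aromatic ring of carbon only, and no measured compound shows what that does here. A large step to a higher number in this assay is therefore expected, possibly smaller than those two. The expected step is a 33-fold higher number from compound 1 to compound 4 (1.52 log units; beyond the scatter). Compound 4 is estimated at 10000 nM, with an expected range of 1500 nM to 40000 nM.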

Compound 4, half-maximal inhibitory concentration: 22400 nM
Compound 4: the middle estimate sits 2.2-fold (0.35 log units) below what was measured; measured number inside the range.
By their numbers in this assay, from the lowest: compound 1; then compounds 4, 3 and 2 (each within the scatter of the next).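

Benzyloxycarbonyl gives a 75-fold higher number from compound 1 to compound 4 (1.87 log units; beyond the scatter) in this assay although it keeps one six-membered aromatic ring of carbon only, so that ring in the entering group does not restore the low number of compound 1. Compound 4, compound 3 and compound 2 lie within the scatter of one another, so the three ester groups are not told apart at this place, with or without the ring. No evidence bears on the size of this step.

On these data alone, what an amine, a carboxylic acid or a longer chain ending in phenyl would do at this place remains open.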